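A few compounds are considered here, and "the series" means these few. Any claim that something is new, unique, unknown or untested is made for them only; others in the source may bear on it.

In a functional assay on A549 cells (Homo sapiens) for cytotoxicity, read by MTT assay, with a stated time of 24 h (a higher number here means a weaker inhibitor, a lower number a stronger inhibitor), three compounds have been measured so far: compound 1 `C/C(=N\NC(=O)/C(C#N)=C/c1ccccc1)c1c(O)c2ccc(O)cc2oc1=O` gives 14800 nM, compound 2 `COc1ccc(/C=C(\C#N)C(=O)N/N=C(\C)c2c(O)c3ccc(O)cc3oc2=O)cc1OC` gives 14300 nM, and compound 3 `C/C(=N\NC(=O)/C(C#N)=C/c1ccc(Br)cc1)c1c(O)c2ccc(O)cc2oc1=O` gives 11400 nM. Compound 3 thus stands level with the other two, its steps to both lying within the scatter. Compound 4 `C/C(=N\NC(=O)/C(C#N)=C/c1ccc(N(C)C)cc1)c1c(O)c2ccc(O)cc2oc1=O` carries dimethylamino in place of bromo on an aromatic carbon, para to a large group: dimethylamino in place of bromo on an aromatic carbon. For the measured compounds named here, three measured steps bear on this change, since each alters the same aromatic end of the molecule: a 1.3-fold lower number from compound 1 to compound 3 (0.11 log units; within the scatter), a 1.0-fold lower number from compound 1 to compound 2 (0.01 log units; within the scatter) and a 1.3-fold lower number from compound 2 to compound 3 (0.10 log units; within the scatter). Going by the values given here, all three stay within the scatter, although no measured compound yet carries dimethylamino. No step beyond the scatter is therefore expected in this assay, and no direction can be predicted with confidence. The expected change is a 1.1-fold higher number from compound 3 to compound 4 (0.06 log units; within the scatter). For compound 4, the estimated value is 13000 nM, with an expected range from 7000 nM to 24000 nM.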

Compound 4, half-maximal inhibitory concentration: 4310 nM
Beside the measured number, compound 4's estimate is 3.0-fold (0.48 log units) above it; the measured number lies below the stated range.
By their numbers in this assay, from the lowest: compound 4; then compounds 3, 2 and 1 (each within the scatter of the next).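

In this assay, the aromatic carbon para to a large group proves able to shift the number: dimethylamino in place of bromo gives a 2.6-fold lower number from compound 3 to compound 4 (0.42 log units; beyond the scatter). The other two comparisons point the same way, with a 3.3-fold lower number from compound 2 to compound 4 (0.52 log units; beyond the scatter) and a 3.4-fold lower number from compound 1 to compound 4 (0.54 log units; beyond the scatter), so 4-(dimethylamino)phenyl stands apart from phenyl, 3,4-dimethoxyphenyl and 4-bromophenyl, whose steps among themselves all lie within the scatter. No measurement here explains why this group differs from the other three.

For the compounds shown here, only one compound carries dimethylamino, so it remains open whether a smaller amine such as unsubstituted amino, a cyclic amine such as pyrrolidine or a carboxylic acid at the same position would give a similar number. From the compounds shown here alone, it also remains open whether the step seen in this assay would carry over to any other cell line.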